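A few compounds are considered here, and "the series" means these few. Any claim that something is new, unique, unknown or untested is made for them only; others in the source may bear on it.

Measured so far in a functional assay on SiHa cells (Homo sapiens) for cytotoxicity, read by MTT assay, with a stated time of 48 h; a lower number here means a stronger inhibitor, a higher number a weaker inhibitor:
compound 1 `CCCCCCCCCCCCNC(=O)[C@@H](NC(=O)/C=C/c1ccccc1)[C@@H](C)O` gives only an assay limit, > 200000 nM.
compound 2 `CCCCCCCCCCCCCCNC(=O)[C@@H](NC(=O)c1cc2ccccc2o1)[C@@H](C)O` gives 14200 nM.
compound 3 `CCCCCCCCCCCCCCNC(=O)[C@@H](NC(=O)c1cc2ccccc2n1C)[C@@H](C)O` gives 26500 nM.

Going by the values given here, compound 3 holds the higher of the two numbers in this assay, and the only step between them, a 1.9-fold higher number from compound 2 to compound 3 (0.27 log units; within the scatter), stays within the scatter; the third value is a limit. Compound 1 sits at the limit of > 200000 nM in this assay, at which 1 of the 3 values shown sits.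

Compound 4 `CCCCCCCCCCCCCCNC(=O)[C@@H](NC(=O)/C=C/c1ccccc1)[C@@H](C)O` is the next case. The change is 2-phenylethenyl in place of 1-methyl-1H-indol-2-yl on a carbonyl carbon. Among the compounds with values here, no measured step covers this exchange: the single measured step replaced one bicyclic aromatic group by another and did not move the number beyond the scatter, so it gives little guidance on swapping in an open 2-phenylethenyl group. What bears on it more directly is compound 1, which carries the same 2-phenylethenyl group on the carbonyl carbon and reports only a limit in this assay. An increase is therefore expected for compound 4, a 5.7-fold higher number from compound 3 to compound 4 (0.75 log units; beyond the scatter), with a fair chance that this assay again returns only a limit. Compound 4 is estimated at 150000 nM, within the range 40000 nM to 400000 nM.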

Compound 4, half-maximal inhibitory concentration: 35800 nM
The estimate for compound 4 lay 4.2-fold (0.62 log units) above the measured number, outside the stated range (below it).
By their numbers in this assay, from the lowest: compounds 2, 3 and 4 (each within the scatter of the next, the first and the last beyond it). At a limit, above all of these: compound 1.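

At this place, on a carbonyl carbon, the open 2-phenylethenyl group does not separate from 1-methyl-1H-indol-2-yl in this assay (a 1.4-fold higher number from compound 3 to compound 4 (0.13 log units; within the scatter)), whereas the exchange against 1-benzofuran-2-yl gives a modest step (a 2.5-fold higher number from compound 2 to compound 4 (0.40 log units; beyond the scatter)). Going by these compounds alone, with 2-phenylethenyl held constant, the chain carries a clear effect that the earlier compounds could not show, since extending it by ethyl in place of hydrogen on a saturated chain carbon gives an at least 5.5-fold lower number from compound 1 to compound 4 (0.74 log units; beyond the scatter). Compound 1 gives a limit and not a number, so this step has only a bound: the limit of > 200000 nM in this assay, at which 1 of the 4 values shown sits.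

From the compounds shown here alone, whether a longer chain than that of compound 4 lowers the number again remains open. Also open, going by these compounds, is how an amine or a carboxylic acid in place of 2-phenylethenyl on the carbonyl carbon would read.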